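The source may hold more compounds than are shown below. What is called first, only, known or untested is meant among the compounds shown, and "the series" means these compounds.

Compounds measured in a functional assay on HeLa cells (Homo sapiens) for cytotoxicity, read by MTT assay, with a stated time of 72 h; a higher number here means a weaker inhibitor, a lower number a stronger inhibitor:
- Compound 1 `Nn1c(SCc2ccccc2)nnc1-c1c[nH]c2ccccc12`: 2300 nM
- Compound 2 `Nn1c(SCc2ccccc2[N+](=O)[O-])nnc1-c1c[nH]c2ccccc12`: 2520 nM
- Compound 3 `Nn1c(SCc2ccc([N+](=O)[O-])cc2)nnc1-c1c[nH]c2ccccc12`: 250 nM

Compound 3 has the lowest number of the three, and its gaps to both others lie beyond the scatter. The next compound, compound 4 `Nn1c(SCc2ccc(Br)cc2)nnc1-c1c[nH]c2ccccc12`, keeps the shared core and has bromo in place of nitro on an aromatic carbon.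

Going by the values given here, two measured steps bear on this change, each putting nitro in place of hydrogen on an aromatic carbon. One is a 1.1-fold higher number from compound 1 to compound 2 (0.04 log units; within the scatter). The other, at the place where compound 4 carries its bromo, is a 9.2-fold lower number from compound 1 to compound 3 (0.96 log units; beyond the scatter). Among the compounds with values here, no measured compound carries bromo, so the data cannot show how closely it tracks nitro. Part of the gain in a 9.2-fold lower number from compound 1 to compound 3 (0.96 log units; beyond the scatter) is therefore expected to be lost, which points to a moderately higher number in this assay. The expected change is a 3.0-fold higher number from compound 3 to compound 4 (0.48 log units; beyond the scatter). For compound 4 the estimated value is 750 nM, with an expected range of 170 nM to 2800 nM.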

Compound 4, half-maximal inhibitory concentration: 8000 nM
Compound 4: middle estimate off by 11-fold (1.03 log units), on the low side, and the stated range ends below it.
By their numbers in this assay, from the lowest: compound 3; then compounds 1 and 2 (each within the scatter of the next); then compound 4.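

In this assay, the gain seen with nitro does not carry over to bromo at this position: there is a 32-fold higher number from compound 3 to compound 4 (1.51 log units; beyond the scatter), and the change reverses the direction seen with nitro, with a 3.5-fold higher number from compound 1 to compound 4 (0.54 log units; beyond the scatter). Going by these compounds alone, the earlier compounds showed only that a group at this position could lower the number, whereas these results show that a group here can move it either way relative to hydrogen, so the outcome depends on which group is present, not merely on the position being filled. Nothing available explains why nitro and bromo differ in this way. As far as these compounds go, whether a nitrile, a chloro group or an amine at this position would fall nearer compound 3 or compound 4 remains open. So does how bromo would behave at the position where compound 2 carries its nitro.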